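Two Single Changes Combined in One Compound

This account rests on a few compounds, and the source may have more. Where it says the series, first, only, none or still open, it means among the compounds named here.

Compound 1 `CN1CCN(CCCSc2nc3ccccc3[nH]2)CC1` gives 77900 nM in a functional assay on MCF7 cells (Homo sapiens) for cytotoxicity, read by MTT assay, with a stated time of 24 h; a lower number here means a stronger inhibitor, a higher number a weaker inhibitor.
Compound 2 `CCOc1ccccc1N1CCN(CCCSc2nc3ccccc3[nH]2)CC1` gives 32700 nM in this assay.
Compound 3 `CN1CCN(CCCSc2nc3cc(Cl)ccc3[nH]2)CC1` gives 13900 nM in this assay.

Compound 3 has the lowest of the three numbers; compound 2 is nearest and compound 1 furthest, both separated from it beyond the scatter. Compound 3 differs from compound 1 only by the chloro, the step of a 5.6-fold lower number from compound 1 to compound 3 (0.75 log units; beyond the scatter). Compound 4 `CCOc1ccccc1N1CCN(CCCSc2nc3cc(Cl)ccc3[nH]2)CC1` is not yet measured; it differs from compound 3 in one place: 2-ethoxyphenyl in place of methyl on an amine nitrogen in a ring. Going by the values given here, the one step that bears on this change is a 2.4-fold lower number from compound 1 to compound 2 (0.38 log units; beyond the scatter), the same exchange made on the shared core without chloro. If the two changes add, compound 4 is expected to show a 2.4-fold lower number from compound 3 to compound 4 (0.38 log units; beyond the scatter) in this assay. Compound 4 is therefore estimated at 5800 nM, within a range from 2500 nM to 14000 nM.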

Compound 4, half-maximal inhibitory concentration: 27700 nM
For compound 4 the middle estimate is 4.8-fold (0.68 log units) below the measured one; measured number outside the range, above it.
By their numbers in this assay, from the lowest: compounds 3, 4 and 2 (each within the scatter of the next, the first and the last beyond it); then compound 1.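

On the core with chloro, 2-ethoxyphenyl in place of methyl on the amine nitrogen in the ring gives a 2.0-fold higher number from compound 3 to compound 4 (0.30 log units; within the scatter) in this assay, so the exchange does not carry over from the core without chloro: the same change on two cores in this assay, a 2.4-fold lower number (0.38 log units; beyond the scatter) from compound 1 to compound 2 and a 2.0-fold higher number (0.30 log units; within the scatter) from compound 3 to compound 4, 4.7-fold (0.68 log units) apart, beyond the scatter of two such steps. Chloro in place of hydrogen on the aromatic carbon gives a 1.2-fold lower number from compound 2 to compound 4 (0.07 log units; within the scatter), so what it does depends on the group on that nitrogen: the same change on two cores in this assay, a 5.6-fold lower number (0.75 log units; beyond the scatter) from compound 1 to compound 3 and a 1.2-fold lower number (0.07 log units; within the scatter) from compound 2 to compound 4, 4.7-fold (0.68 log units) apart, beyond the scatter of two such steps. In these four compounds, the two changes do not add.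

As far as these compounds go, it remains open whether an unsubstituted phenyl or an ethyl on that nitrogen would follow methyl or 2-ethoxyphenyl. From the compounds shown here alone, it is also open whether fluoro in place of chloro would show the same dependence.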